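Ethyl for methylamino on a sulfonyl sulfur

A few compounds are considered here, and "the series" means these few. Any claim that something is new, unique, unknown or untested is made for them only; others in the source may bear on it.

Measured so far in an ADME assay on H9c2 cells (Rattus norvegicus) for cytotoxicity; a higher number here means a weaker inhibitor, a lower number a stronger inhibitor:
Compound 1 `O=C(Nc1nc2cc(F)c(C(F)(F)F)cc2s1)C1CC1`: > 50000 nM (a limit)
Compound 2 `CNS(=O)(=O)c1cc2sc(NC(=O)C3CC3)nc2cc1F`: > 50000 nM (a limit)

In this assay compound 2 stands at > 50000 nM, which is a limit and not a number. Compound 3 `CCS(=O)(=O)c1cc2sc(NC(=O)C3CC3)nc2cc1F` keeps the shared core and alters one group: ethyl in place of methylamino on a sulfonyl sulfur. For the measured compounds named here, the only measured step to compare is a step that the two limits leave unreadable from compound 1 to compound 2, and its size cannot be read. The evidence so far is the limit of > 50000 nM in this assay, at which 2 of the 2 values shown sit, so the data hold no measured step size to carry over. Resting on that limit of compound 2 at > 50000 nM, no step beyond the scatter is expected in this assay, in either direction. The expected step is a number no higher from compound 2 to compound 3 (the limit leaves the size open). For compound 3 the estimated value is 50000 nM, with an expected range from 20000 nM to 100000 nM.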

Compound 3, half-maximal inhibitory concentration: > 50000 nM
Compound 3 ended at the assay's limit; the forecaster's own chance of this, stated with the estimate: 85%; the middle value sits exactly at the limit.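

Compound 1, compound 2 and compound 3 each end at a limit rather than a number, so no step among them can be read in this assay: the limit of > 50000 nM in this assay, at which 3 of the 3 values shown sit.

The compounds shown leave open whether these three differ at all in this assay, and which changed group, if any, would shift the value.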